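This account rests on a few compounds, and the source may have more. Where it says the series, first, only, none or still open, it means among the compounds named here.

Among the compounds with values here, compound 2 `NC(=O)c1ccc2c(ccn2-c2ccc(NC(=O)Nc3ccc(Cl)c(Cl)c3)cc2)n1` stands with the highest of the two numbers so far in an ADME assay on HS27 cells (Homo sapiens) for cytotoxicity, read by MTT assay (a higher number here means a weaker inhibitor, a lower number a stronger inhibitor), giving 6600 nM; compound 1 `COC(=O)c1ccc2c(ccn2-c2ccc(NC(=O)Nc3ccc(Cl)c(Cl)c3)cc2)n1` gives 2800 nM in this assay, and the only measured step is a 2.4-fold higher number from compound 1 to compound 2 (0.37 log units; beyond the scatter), a change on the carbonyl carbon. Within the data shown here, compound 3 `NC(=O)c1ccc2c(ccn2-c2ccc(NC(=O)Nc3ccc(Cl)c(C(F)(F)F)c3)cc2)n1` differs from compound 2 by trifluoromethyl in place of chloro on an aromatic carbon, a change on the 3,4-dichlorophenyl, where no measured step applies, so nothing bears on it directly. The expected step is therefore no change at the digits printed from compound 2 to compound 3 (within the scatter), nothing beyond the scatter. Compound 3 is estimated at 6600 nM, within 2500 nM to 17000 nM.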

Compound 3, half-maximal inhibitory concentration: > 10000 nM
Compound 3 ended at the assay's limit (the forecaster's own chance of this, stated with the estimate: 10%); middle value at least 1.5-fold (0.18 log units) from the limit.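

In this assay compound 3 gives > 10000 nM, a limit of the assay and not a number. Within the data shown here, the first measured change on the 3,4-dichlorophenyl reads an at least 1.5-fold higher number from compound 2 to compound 3 (0.18 log units; that floor lies within the scatter), so trifluoromethyl in place of chloro, at this position ortho to a chloro group, did not bring the number down, though the size of the step is unknown. Only one of the compounds shown reaches that ceiling: the limit of > 10000 nM in this assay, at which 1 of the 3 values shown sits.

Going by these compounds, how far compound 3 lies past the limit stays open. So does the effect of an amine or a nitrile at this position.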